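A few compounds are considered here, and "the series" means these few. Any claim that something is new, unique, unknown or untested is made for them only; others in the source may bear on it.

Compound 1 `CCCCCCCCCCCC(=O)OC[C@H](CSC[C@@H](N)C(=O)N[C@@H](C)CO)OC(=O)CCCCCCCCCCC` gives 1560 nM in an assay on HEK293 cells for agonist activity at Toll-like receptor 2 (Homo sapiens); on this read-out lower numbers stand for an effect already at smaller amounts and higher numbers for an effect only at larger amounts of compound.
Compound 2 `CCCCCCCCCCCC(=O)OC[C@H](CSC[C@@H](N)C(=O)NCCO)OC(=O)CCCCCCCCCCC` gives 24 nM in this assay.
Compound 3 `CCCCCCCCCCCC(=O)OC[C@H](CSC[C@@H](N)C(=O)NC(CC)COC)OC(=O)CCCCCCCCCCC` gives 71.8 nM in this assay.

On these three numbers compound 3 stands second highest: its nearest neighbour is reached by a 3.0-fold higher number from compound 2 to compound 3 (0.48 log units; beyond the scatter), its furthest by a 22-fold lower number from compound 1 to compound 3 (1.34 log units; beyond the scatter). Compound 4 `CCCCCCCCCCCC(=O)OC[C@H](CSC[C@@H](N)C(=O)NCCCCCCCCCC(=O)O)OC(=O)CCCCCCCCCCC` differs from compound 3 by 9-carboxynonyl in place of 1-(methoxymethyl)propyl on an amide-type nitrogen. Both measured steps that change the group on that nitrogen bear on this: one large, a 22-fold lower number from compound 1 to compound 3 (1.34 log units; beyond the scatter), one modest, a 3.0-fold higher number from compound 2 to compound 3 (0.48 log units; beyond the scatter). Among the measured compounds shown here, no measured compound carries a 9-carboxynonyl chain, so the direction is uncertain, and in this assay a modest step is expected for compound 4, a 1.0-fold lower number from compound 3 to compound 4 (0.01 log units; within the scatter). Compound 4 is therefore estimated at 70 nM, with a range from 12 nM to 450 nM.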

Compound 4, half-maximal effective concentration: 4400 nM
Beside the measured number, compound 4's estimate is 63-fold (1.80 log units) below it; measured number outside the range, above it.
By their numbers in this assay, from the lowest: compound 2; then compound 3; then compound 1; then compound 4.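

Among the compounds shown here, putting 9-carboxynonyl on the amide-type nitrogen shows that this position can lose far more than the earlier compounds revealed: in this assay there is a 61-fold higher number from compound 3 to compound 4 (1.79 log units; beyond the scatter) and also a 180-fold higher number from compound 2 to compound 4 (2.26 log units; beyond the scatter) with this chain in place. Even against the previous highest number there is a 2.8-fold higher number from compound 1 to compound 4 (0.45 log units; beyond the scatter) so compound 4 now stands highest of the four. Nothing measured here explains this rise. Still open, going by these compounds, is whether the chain length or its carboxylic acid end drives the rise: a plain decyl chain, or the same chain ending in an amine, would separate the two.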